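Trimethoxyphenyl series: indole to methoxyphenyl swap

This account rests on a few compounds, and the source may have more. Where it says the series, first, only, none or still open, it means among the compounds named here.

In a functional assay on HeLa cells (Homo sapiens) for inhibition, read by CCK-8 assay, with a stated time of 48 h (a higher number here means a weaker inhibitor, a lower number a stronger inhibitor), compound 2 `COc1cc(-c2ccnc3cc(-c4ccc5c(ccn5C)c4)nn23)cc(OC)c1OC` gives 19 nM, the lowest of the three numbers; compound 1 `COc1cc(-c2ccnc3cc(-c4cn(CO)c5ccccc45)nn23)cc(OC)c1OC` gives 103 nM and compound 3 `COc1cc(-c2ccnc3cc(-c4cn(C(=O)OC(C)(C)C)c5ccccc45)nn23)cc(OC)c1OC` gives 3770 nM. Going by the values given here, the one measured step, a 37-fold higher number from compound 1 to compound 3 (1.56 log units; beyond the scatter), concerns a substituent on an aromatic nitrogen and does not touch the place changed in compound 4 `COc1ccc(-c2cc3nccc(-c4cc(OC)c(OC)c(OC)c4)n3n2)cc1`, which differs from compound 2 by 4-methoxyphenyl in place of 1-methyl-1H-indol-5-yl on an aromatic carbon. Among the compounds with values here, no measured step replaces the whole 1-methyl-1H-indol-5-yl group, so the expectation rests only on the spread seen so far. A step toward a higher number is expected, a 2.6-fold higher number from compound 2 to compound 4 (0.42 log units; beyond the scatter), smaller than the step from hydroxymethyl to tert-butoxycarbonyl. Compound 4 is therefore estimated at 50 nM, within 12 nM to 220 nM.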

Compound 4, half-maximal inhibitory concentration: 373 nM
The estimate for compound 4 lay 7.5-fold (0.87 log units) below the measured number; measured number above the stated range.
By their numbers in this assay, from the lowest: compound 2; then compound 1; then compound 4; then compound 3.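

In this assay, a 20-fold higher number from compound 2 to compound 4 (1.29 log units; beyond the scatter) when 4-methoxyphenyl replaces 1-methyl-1H-indol-5-yl, a large step beyond the scatter. The number therefore responds to the whole group on this aromatic carbon of the five-membered ring with 2 nitrogen, not only to a substituent on an aromatic nitrogen. No data available here explain the step.

The swap both removes the five-membered aromatic ring and brings in methoxy, and the compounds shown do not separate these two changes. On these data alone, how an amine or a carboxylic acid in place of that methoxy would read also remains open.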